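The source may report more compounds than this note shows. Statements on the series, on what has been measured and on what is new or still open speak of the compounds shown alone.

Measured so far in a functional assay on CEM-SS cells (Homo sapiens) for cytotoxicity (a lower number here means a stronger inhibitor, a higher number a weaker inhibitor), are two compounds:

compound 1 `Cc1ccc(Cn2c(N)nc3cc(Cl)c(Cl)cc32)cc1` gives 40000 nM
compound 2 `Cc1ccc(Cn2c(Cl)nc3cc(Cl)c(Cl)cc32)cc1` gives > 100000 nM (a limit of the assay)

Compound 2 has no exact number, and its > 100000 nM is only a limit of the assay. Compound 3 `FC(F)(F)c1ccc(Cn2c(Cl)nc3cc(Cl)c(Cl)cc32)cc1` has trifluoromethyl in place of methyl on an aromatic carbon and is otherwise the same as compound 2. Going by the values given here, only one measured step is available, and an at least 2.5-fold higher number from compound 1 to compound 2 (0.39 log units; beyond the scatter) is a change made at a different place in the molecule. Among the compounds with values here, it therefore gives no direct measure of this swap, and no measured step tests the exchange of methyl for trifluoromethyl. Within the data shown here, the expectation is a small change at most, with no step clearly beyond the scatter in this assay and no firm direction. The expected step is an at least 1.2-fold lower number from compound 2 to compound 3 (0.09 log units; that floor lies within the scatter) on this estimate. For compound 3 the estimated value is 80000 nM, with an expected range from 30000 nM to 150000 nM.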

Compound 3, half-maximal inhibitory concentration: > 100000 nM
Compound 3 gave a limit, no number; the forecaster's own chance of this, stated with the estimate: 60%; middle value at least 1.2-fold (0.09 log units) from the limit.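

Going by these compounds alone, no step from compound 2 to compound 3 can be read, since neither compound gives a number, only a limit: the limit of > 100000 nM in this assay, at which 2 of the 3 values shown sit.

The compounds shown leave open whether trifluoromethyl in place of methyl changes the result at all, and in which direction.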